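A few compounds are considered here, and "the series" means these few. Any claim that something is new, unique, unknown or untested is made for them only; others in the source may bear on it.

Compound 3 `Cn1ccc2cc(-c3cnccc3/C=C/C(=O)O)ccc21` gives the lowest of the three measured numbers in an assay on a protein complex for inhibition of CDK8/Cyclin C (Homo sapiens), with a stated time of 1 h (on this read-out higher numbers stand for weaker inhibition and lower numbers for stronger inhibition), namely 26.8 nM. Compound 1 `O=C(/C=C/c1ccncc1-c1ccc2[nH]ccc2c1)N1CCOCC1` gives 190 nM in this assay, and compound 2 `Cn1ccc2cc(-c3cnccc3/C=C/C(=O)N3CCOCC3)ccc21` gives 247 nM. Both of those sit beyond the scatter from compound 3, so compound 3 is the strongest inhibitor among the measured compounds. Compound 4 `O=C(O)/C=C/c1ccncc1-c1ccc2[nH]ccc2c1` differs from compound 3 in one place: hydrogen in place of methyl on an aromatic nitrogen. The same change, taken in the opposite direction, was already measured between compound 1 and compound 2, where it gave a 1.3-fold higher number from compound 1 to compound 2 (0.11 log units; within the scatter). Since that step stayed within the scatter, the removal of the methyl in compound 4 is expected to leave the number where compound 3 put it, or to move it only slightly. The other measured step, a 9.2-fold lower number from compound 2 to compound 3 (0.96 log units; beyond the scatter), concerns the carbonyl carbon and not the aromatic nitrogen, so it does not bear on the present change. It is the step that brings the number down to where compound 3 stands. Compound 4 is therefore expected to give 22 nM in this assay, with a range from 9 nM to 55 nM. The step this estimate implies is a 1.2-fold lower number from compound 3 to compound 4 (0.09 log units; within the scatter), which stays within the scatter.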

Compound 4, half-maximal inhibitory concentration: 17 nM
Compound 4: middle estimate off by 1.3-fold (0.11 log units), on the high side; measured number inside the range.
By their numbers in this assay, from the lowest: compounds 4 and 3 (each within the scatter of the next); then compounds 1 and 2 (each within the scatter of the next).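

In this assay, the change at this aromatic nitrogen can now be read with hydroxy on the carbonyl carbon as well as with morpholin-4-yl: a 1.6-fold lower number from compound 3 to compound 4 (0.20 log units; within the scatter) stays within the scatter, so hydrogen and methyl give matching numbers on both cores, and the two readings agree: the same change on two cores in this assay, a 1.3-fold higher number (0.11 log units; within the scatter) from compound 1 to compound 2 and a 1.6-fold higher number (0.20 log units; within the scatter) from compound 4 to compound 3, 1.2-fold (0.08 log units) apart, within the scatter of two such steps. Among the compounds shown here, the change at the carbonyl carbon had been seen only with methyl on the nitrogen, and with hydrogen there, hydroxy in place of morpholin-4-yl gives an 11-fold lower number from compound 1 to compound 4 (1.05 log units; beyond the scatter) and so carries over to the second core: the same change on two cores in this assay, a 9.2-fold lower number (0.96 log units; beyond the scatter) from compound 2 to compound 3 and an 11-fold lower number (1.05 log units; beyond the scatter) from compound 1 to compound 4, 1.2-fold (0.08 log units) apart, within the scatter of two such steps. Across these four compounds, the group on the carbonyl carbon separates the numbers beyond the scatter while the group on the aromatic nitrogen does not, and no compound among them goes against this.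

On these data alone, whether an ethyl group or a longer chain on this aromatic nitrogen would also leave the number in place stays open. So does what a methyl ester or a primary amide on the carbonyl carbon would give, and these compounds cannot tell what about the hydroxy lowers the number.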